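This account rests on a few compounds, and the source may have more. Where it says the series, first, only, none or still open, it means among the compounds named here.

Working notes on the aminopyridine-substituted series sharing one core. Compound 1 `CCN(CC)CCN(C)c1ccc(Cn2c(=O)[nH]c3c(N)nc(C(F)(F)F)cc32)cn1` in an in vitro ADME assay on microsomes from liver (Homo sapiens) for pharmacokinetics (on this read-out higher numbers stand for fast clearance and lower numbers for slow clearance), gives 24 mL.min-1.g-1. Compound 3 `CN(C)CCN(C)c1ccc(Cn2c(=O)[nH]c3c(N)nc(C(F)(F)F)cc32)cn1` gives 16 mL.min-1.g-1 in this assay, which sits within the scatter of compound 1; the step is a 1.5-fold lower number from compound 1 to compound 3 (0.18 log units; within the scatter). Compound 2 `Nc1nc(C(F)(F)F)cc2c1[nH]c(=O)n2Cc1ccc(NCc2ccccc2)nc1` in this assay reports only a limit, < 8 mL.min-1.g-1. The step from compound 2 is an at least 2.0-fold higher number from compound 2 to compound 3 (0.30 log units; that floor lies within the scatter), whose floor lies within the scatter. Compound 4 `CN1CCN(c2ccc(Cn3c(=O)[nH]c4c(N)nc(C(F)(F)F)cc43)cn2)CC1` differs from compound 3 in one place: 4-methylpiperazin-1-yl in place of (2-(dimethylamino)ethyl)(methyl)amino on an aromatic carbon. Both steps that bear on the amino substituent at this aromatic carbon stayed within the scatter, so for compound 4 the expected step is a 1.1-fold lower number from compound 3 to compound 4 (0.06 log units; within the scatter), no change beyond the scatter. Compound 4 is thus estimated at 14 mL.min-1.g-1, between 7 mL.min-1.g-1 and 28 mL.min-1.g-1.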

Compound 4, intrinsic clearance in microsomes in the Homo sapiens assay: 30 mL.min-1.g-1
The estimate for compound 4 lay 2.1-fold (0.33 log units) below the measured number; measured number above the stated range.
By their numbers in the Homo sapiens assay, from the lowest: compounds 3, 1 and 4 (each within the scatter of the next). At a limit, below all of these: compound 2.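

In the Homo sapiens assay the ring of 4-methylpiperazin-1-yl, in place of either open amino chain, stays within the scatter: a 1.9-fold higher number from compound 3 to compound 4 (0.27 log units; within the scatter), and a 1.3-fold higher number from compound 1 to compound 4 (0.10 log units; within the scatter). For the compounds shown here, the only step here beyond the scatter starts from a limit, the one of compound 2: an at least 3.7-fold higher number from compound 2 to compound 4 (0.57 log units; beyond the scatter). In a physicochemical assay for lipophilicity (a lower number here means a more polar compound, a higher number a more lipophilic compound), compound 3 gives 1.2 and compound 4 gives 1.8, so the same change does pass the scatter on this read-out: a number 0.60 log units higher from compound 3 to compound 4 (beyond the scatter).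

Open, as far as these compounds go, is how a morpholine or a piperazine without the methyl group on nitrogen would read at this aromatic carbon in the Homo sapiens assay.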